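Shifting the amide's aryl group away from 2-ethylphenyl

This account rests on a few compounds, and the source may have more. Where it says the series, first, only, none or still open, it means among the compounds named here.

Measured so far in a functional assay on MCF7 cells (Homo sapiens) for antiproliferative activity, read by MTT assay, with a stated time of 72 h; on this read-out lower numbers stand for stronger inhibition and higher numbers for weaker inhibition:
- compound 1 `CCc1ccc(C(=O)Nc2ccc3nc(N4CCN(CC)CC4)cc(C)c3c2)cc1` gives 3060 nM
- compound 2 `CCc1ccccc1C(=O)Nc1ccc2nc(N3CCN(CC)CC3)cc(C)c2c1` gives 15800 nM
- compound 3 `CCN1CCN(c2cc(C)c3cc(NC(=O)c4ccc(OC)cc4)ccc3n2)CC1` gives 7690 nM

All three compounds share one core and differ only in the aryl group on the carbonyl carbon of the amide. Compound 2 stands highest of the three numbers, which in this assay means the weakest inhibition: compound 1 to compound 2 shows a 5.2-fold higher number from compound 1 to compound 2 (0.71 log units; beyond the scatter), and compound 2 to compound 3 shows a 2.1-fold lower number from compound 2 to compound 3 (0.31 log units; beyond the scatter). The remaining pair, compound 1 to compound 3, shows a 2.5-fold higher number from compound 1 to compound 3 (0.40 log units; beyond the scatter).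

Compound 4 `CCN1CCN(c2cc(C)c3cc(NC(=O)c4ccc(F)c(F)c4)ccc3n2)CC1` has not yet been measured. The change from compound 2 is 3,4-difluorophenyl in place of 2-ethylphenyl on a carbonyl carbon.

Within the data shown here, two measured steps bear on this. Both steps that replace 2-ethylphenyl with a differently substituted phenyl lowered the number, by the amounts given above, and both were modest yet beyond the scatter. A step of similar kind and size is therefore expected here, in the direction of a lower number. The step from compound 2 to compound 4 is estimated at a 2.6-fold lower number from compound 2 to compound 4 (0.42 log units; beyond the scatter). For compound 4 the expected value in this assay is 6000 nM, within a range from 2000 nM to 18000 nM.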

Compound 4, half-maximal inhibitory concentration: 5230 nM
Compound 4: the middle estimate sits 1.1-fold (0.06 log units) above what was measured, and the stated range covers the measured number.
By their numbers in this assay, from the lowest: compounds 1, 4 and 3 (each within the scatter of the next, the first and the last beyond it); then compound 2.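

In this assay, replacing 2-ethylphenyl with 3,4-difluorophenyl gives a clear drop (a 3.0-fold lower number from compound 2 to compound 4 (0.48 log units; beyond the scatter)), so a third aryl group now sits beyond the scatter from compound 2, which remains the weakest of the four, and no compound shown goes against this. Unlike the earlier replacements, this one carries no ethyl or methoxy group, yet the two swapped groups have the same count of 8 heavy atoms, so the gain does not depend on a change in that count. The new group also cannot be told apart from either earlier replacement, since both comparisons stay within the scatter (a 1.5-fold lower number from compound 3 to compound 4 (0.17 log units; within the scatter); a 1.7-fold higher number from compound 1 to compound 4 (0.23 log units; within the scatter)), and no supporting measurement here explains any of these differences.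

The compounds shown place only an ethyl group in the 2-substituted aryl, so 2-fluorophenyl or 2-methoxyphenyl would help show whether the high number of compound 2 belongs to ethyl or to that placement. Going by these compounds, it also stays open what each fluorine contributes alone, as 4-fluorophenyl or 3-fluorophenyl would show, and how an amine or a carboxylic acid on the ring would behave.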